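Moving the pyridine nitrogen in a hydrazone series

The compounds below may be only part of what the source reports. "The series", "measured", "known", "first", "only" and "open" are said of these compounds alone.

Three hydrazones sharing one core have been tested in a functional assay on PC-3 cells (Homo sapiens) for inhibition; on this read-out higher numbers stand for weaker inhibition and lower numbers for stronger inhibition. Compound 1 `Cc1c(C(=O)N/N=C\c2ccccc2F)oc2cccc(O)c12` gives only a limit of the assay, >= 40000 nM. Compound 2 `Cc1c(C(=O)N/N=C\c2ccc(O)cc2)oc2cccc(O)c12` gives 21700 nM in this assay. Compound 3 `Cc1c(C(=O)N/N=C\c2cccnc2)oc2cccc(O)c12` likewise sits at a limit, >= 40000 nM. The step of an at least 1.8-fold higher number from compound 2 to compound 3 (0.26 log units; that floor lies within the scatter) is only a floor, and a step that the two limits leave unreadable from compound 1 to compound 3 cannot be read, since both of its ends sit at the limit of >= 40000 nM in this assay, at which 2 of the 3 values shown sit. Compound 4 `Cc1c(C(=O)N/N=C\c2ccncc2)oc2cccc(O)c12` differs from compound 3 by pyridin-4-yl in place of pyridin-3-yl on a carbon with a double bond to nitrogen. For the measured compounds named here, no measured step exchanges one pyridyl for another, and every step touching compound 3 is capped by that limit. Compound 4 is therefore expected to stay near the limit, with an estimated 40000 nM (range 15000 nM to 100000 nM). This is expected to amount to a number no higher from compound 3 to compound 4 (the limit leaves the size open), within the scatter.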

Compound 4, half-maximal inhibitory concentration: >= 40000 nM
Compound 4: only a limit was reported; the forecaster's own chance of this, stated with the estimate: 70%; the middle value sits exactly at the limit.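

Compound 4 shows that pyridin-4-yl on this carbon, like pyridin-3-yl, gives only a limit of the assay, so moving the ring nitrogen yields no readable change. Replacing 4-hydroxyphenyl with pyridin-4-yl gives an at least 1.8-fold higher number from compound 2 to compound 4 (0.26 log units; that floor lies within the scatter). The steps to compound 4 from compound 1 and compound 3 cannot be read, because both ends of each sit at one limit: the limit of >= 40000 nM in this assay, at which 3 of the 4 values shown sit.

As far as these compounds go, it remains open whether compound 1, compound 3 and compound 4 truly differ. Also open, from the compounds shown here alone, is whether pyridin-2-yl or an aminophenyl group on this carbon would give a measurable number.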